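The source may report more compounds than this note shows. Statements on the series, on what has been measured and on what is new or still open speak of the compounds shown alone.

Working notes on the series. In an ADME assay for permeability, using PAMPA, with a stated time of 10 h, tested at 100 ug/mL (a higher number here means that the compound crosses the layer faster, a lower number that the compound crosses the layer more slowly), compound 1 `Oc1ccc2cc(-c3ccc(O)c4ncccc34)oc2c1` gives 15.8 10^-6 cm/s and compound 2 `Oc1ccc2oc(-c3ccc(O)c4ncccc34)cc2c1` gives 15.5 10^-6 cm/s. Compound 3 `Oc1cc(O)c2cc(-c3ccc(O)c4ncccc34)oc2c1` gives 2.6 10^-6 cm/s, the lowest number of the three, with both other values beyond the scatter from it.

The next compound is compound 4 `Oc1cc(O)c2cc(-c3cc(I)c(O)c4ncccc34)oc2c1`, which differs from compound 3 by one substitution: iodo in place of hydrogen on an aromatic carbon. This is iodo in place of hydrogen on an aromatic carbon, ortho to a hydroxy group, on the six-membered aromatic ring of carbon only.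

For the measured compounds named here, only one measured step changes a single place: a 6.1-fold lower number from compound 1 to compound 3 (0.78 log units; beyond the scatter). That step is modest and beyond the scatter, but it brings in hydroxy in place of hydrogen on an aromatic carbon, at a different place on the shared core. It therefore shows what one aromatic substitution can do in this series, without setting a direction for iodo. Going by the values given here, no measured pair carries an iodo group, so the expectation is weakly founded.

In this assay, no step beyond the scatter is expected, with a slight lean towards a higher number. The expected step is a 1.3-fold higher number from compound 3 to compound 4 (0.13 log units; within the scatter). For compound 4 the estimated value is 3.5 10^-6 cm/s, with an expected range from 1.3 10^-6 cm/s to 10 10^-6 cm/s.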

Compound 4, apparent permeability: 0.8 10^-6 cm/s
Estimate against measurement, compound 4: 4.4-fold (0.64 log units) above, outside the stated range (below it).
By their numbers in this assay, from the lowest: compound 4; then compound 3; then compounds 2 and 1 (each within the scatter of the next).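

In this assay iodo in place of hydrogen on an aromatic carbon, ortho to a hydroxy group, gives a 3.3-fold lower number from compound 3 to compound 4 (0.51 log units; beyond the scatter) and so shows that the number responds to substitution at this position on the six-membered aromatic ring of carbon only. For the compounds shown here, until now the only single-place step was the one that brings in hydroxy, a 6.1-fold lower number from compound 1 to compound 3 (0.78 log units; beyond the scatter) at a different place on the shared core, so the series now holds two aromatic substitutions that both lead to a lower number, one with a hydroxy group and one with an iodo group, for which no hydrogen-bond donor or acceptor is counted. Nothing measured on these compounds bears on what lies behind the iodo step.

Going by these compounds, whether this step belongs to iodo itself or to any group at this carbon stays open, and a chloro group, a methyl group or an amine at the same place would separate the two. Also open, on these data alone, is whether iodo at this position gives a step of similar size on compound 1, which lacks the added hydroxy group of compound 3.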